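The source may report more compounds than this note shows. Statements on the series, on what has been measured and on what is new or still open speak of the compounds shown alone.

Measured so far:
compound 1 `COc1cccc(/C=C2\CCC/C(=C\c3ccc(O)cc3)C2=O)c1OC` — > 50000 nM
compound 2 `COc1cccc(/C=C2\CCC/C(=C\c3cccc(Cl)c3Cl)C2=O)c1OC` — > 50000 nM
compound 3 `COc1ccc(/C=C2\CCC/C(=C\c3ccc(O)cc3)C2=O)cc1OC` — 26100 nM

All three were tested in an ADME assay on NHDF cells (Homo sapiens) for cytotoxicity, read by MTT assay, with a stated time of 72 h; on this read-out lower numbers stand for stronger inhibition and higher numbers for weaker inhibition. For compound 1 the value > 50000 nM is a limit of this assay and not a number. For compound 2 the value > 50000 nM is likewise a limit. Compound 3 is the only one of the three with a real number, 26100 nM in this assay. The change from compound 1 to compound 2 is 2,3-dichlorophenyl in place of 4-hydroxyphenyl on a double-bonded chain carbon bound to a double-bonded ring carbon, and its step is a step that the two limits leave unreadable from compound 1 to compound 2. Compound 3 and compound 1 are built from the same atoms joined differently; the difference between the two cores is not broken down here.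

Compound 4 `COc1ccc(/C=C2\CCC/C(=C\c3cccc(Cl)c3Cl)C2=O)cc1OC` has not yet been measured. Its change from compound 3 is 2,3-dichlorophenyl in place of 4-hydroxyphenyl on a double-bonded chain carbon bound to a double-bonded ring carbon, the same change as from compound 1 to compound 2. Compound 4 is expected to show a step of a 1.5-fold higher number from compound 3 to compound 4 (0.19 log units; within the scatter) in this assay. That rests on compound 2, whose limit sits at the limit of > 50000 nM in this assay, at which 2 of the 3 values shown sit. Compound 4 is expected near 40000 nM, between 15000 nM and 100000 nM.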

Compound 4, half-maximal inhibitory concentration: 18500 nM
Compound 4: the middle estimate sits 2.2-fold (0.33 log units) above what was measured; the measured number falls inside the stated range.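

In this assay, putting 2,3-dichlorophenyl in place of 4-hydroxyphenyl on the core of compound 3 gives a 1.4-fold lower number from compound 3 to compound 4 (0.15 log units; within the scatter), so on this core the swap cannot be told apart from the ordinary spread of repeated measurements. Within the data shown here, compound 1 and compound 2 each give only a limit of the assay and not a number, so the same swap cannot be read on their core: the limit of > 50000 nM in this assay, at which 2 of the 4 values shown sit. The pairs therefore show a result within the scatter on one core only; they do not show that the swap behaves alike on both cores, because only one of the two steps has a size.

The compounds shown carry only 4-hydroxyphenyl or 2,3-dichlorophenyl at this place, so it stays open what a phenyl ring bearing an amine or a carboxylic acid would give there. From the compounds shown here alone, it also stays open whether the step between these two groups would look the same in any read-out other than this assay.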